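This account rests on a few compounds, and the source may have more. Where it says the series, first, only, none or still open, it means among the compounds named here.

Compound 1, `CNC(=O)c1cc(Oc2ccc3oc(Nc4ccc(C(C)C)cc4)nc3c2)ccn1`, gives 10 10^-6 cm/s in an ADME assay on Caco-2 cells (Homo sapiens) for permeability, in the apical to basolateral direction; on this read-out higher numbers stand for higher permeability and lower numbers for lower permeability. Compound 2, `CNC(=O)c1cc(Oc2ccc3oc(Nc4ccc(OC(F)(F)F)cc4)nc3c2)ccn1`, gives 10 10^-6 cm/s in this assay. The change between them is trifluoromethoxy in place of isopropyl on an aromatic carbon, and it produced no change at the digits printed from compound 1 to compound 2 (within the scatter). Compound 3, `CNC(=O)c1cc(Oc2ccc3sc(Nc4ccc(C(C)C)cc4)nc3c2)ccn1`, carries a different core; the difference between the two cores is not broken down here. In this assay compound 3 gives 10 10^-6 cm/s, level with compounds 1 and 2 within the scatter. Compound 4, `CNC(=O)c1cc(Oc2ccc3sc(Nc4ccc(OC(F)(F)F)cc4)nc3c2)ccn1`, is related to compound 3 by trifluoromethoxy in place of isopropyl on an aromatic carbon, the same change that was made from compound 1 to compound 2, at the same kind of place. The step from compound 3 to compound 4 is expected to be no change at the digits printed from compound 3 to compound 4 (within the scatter), because the same change earlier produced no change at the digits printed from compound 1 to compound 2 (within the scatter). For compound 4 the estimate is 10 10^-6 cm/s, from 5 10^-6 cm/s to 20 10^-6 cm/s.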

Compound 4, apparent permeability: 10 10^-6 cm/s
Beside the measured number, compound 4's estimate shows no gap at the digits printed, and the stated range covers the measured number.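

In this assay, putting trifluoromethoxy in place of isopropyl on the second core gave no change at the digits printed from compound 3 to compound 4 (within the scatter). Set beside the earlier step, the change reads the same on both cores: the same change on two cores in this assay, no change at the digits printed (within the scatter) from compound 1 to compound 2 and no change at the digits printed (within the scatter) from compound 3 to compound 4, 1.0-fold (0.00 log units) apart, within the scatter of two such steps This shows that, on these two cores and in this one read-out, the step carried over from one core to the other, but with only two pairs it does not show that it would carry to any further core or that it would hold in any other assay.

The compounds shown leave open how a group of another kind on that aromatic carbon, such as an amine or a carboxylic acid, would read in this assay.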